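This account rests on a few compounds, and the source may have more. Where it says the series, first, only, none or still open, it means among the compounds named here.

Compound 1 `Cc1cn2c(-c3cn[nH]c3)cnc2c(Nc2cc(Cn3cccn3)ns2)n1` gives "not determined" (no result reported) in an ADME assay on the whole organism for pharmacokinetics, with Rattus norvegicus as the target, with a stated time of 6 h, at a dose of 10 mg/kg by the oral route; a higher number here means more compound in the circulation at the dose given, a lower number less compound in the circulation; no number for it exists there, so it gives no starting point of its own. Two close relatives were measured. Compound 2 `Cc1ccc(Cc2cc(Nc3nc(C)cn4c(-c5cn[nH]c5)cnc34)sn2)nc1` gives 1370 ng.h/mL in this assay, and compound 3 `Cc1cn2c(-c3cn[nH]c3)cnc2c(Nc2cc(Cc3ccc(F)cn3)ns2)n1` gives 2240 ng.h/mL. Among the compounds with values here, the one step between them, a 1.6-fold higher number from compound 2 to compound 3 (0.21 log units; within the scatter), leaves the area under the concentration-time curve essentially unchanged.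

Compound 4 `COc1cccc(Cc2cc(Nc3nc(C)cn4c(-c5cn[nH]c5)cnc34)sn2)n1` differs from compound 1 in one place: 6-methoxypyridin-2-yl in place of 1H-pyrazol-1-yl on a saturated chain carbon bound to an aromatic carbon. Compound 2 and compound 3 already carry a six-membered aromatic ring on a saturated chain carbon bound to an aromatic carbon, where compound 1 carries the five-membered one, and both land in a similar range.

Within the data shown here, no measured step matches the change from compound 1 to compound 4, so no direction can be expected for it. Compound 4 is estimated to give 1500 ng.h/mL in this assay, with a range from 400 ng.h/mL to 5000 ng.h/mL. This expectation rests on compound 2, which gives 1370 ng.h/mL, and on compound 3, which gives 2240 ng.h/mL.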

Compound 4, area under the concentration-time curve: 2300 ng.h/mL
Estimate against measurement, compound 4: 1.5-fold (0.19 log units) below, within the range that was stated.
By their numbers in this assay, from the lowest: compounds 2, 3 and 4 (each within the scatter of the next).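

With 6-methoxypyridin-2-yl on the saturated chain carbon, a third pyridine group joins 5-methylpyridin-2-yl and 5-fluoropyridin-2-yl, and in this assay the three stand level: the reading shows a 1.0-fold higher number from compound 3 to compound 4 (0.01 log units; within the scatter) and a 1.7-fold higher number from compound 2 to compound 4 (0.23 log units; within the scatter). Across compound 2, compound 3 and compound 4, then, exchanging one of these pyridine groups for another leaves the area under the concentration-time curve unchanged within the scatter. Nothing available explains why these readings stay level.

In this assay compound 1 gives "not determined" (no result reported), so the 1H-pyrazol-1-yl group cannot yet be compared with any of the pyridine groups. Also open, from the compounds shown here alone, is whether a different kind of group at this place, such as an amine or a carboxylic acid, would leave the reading where these three stand.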